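Alpha-Methyl Branching on the Acid Chain of Compound 2

The source may hold more compounds than are shown below. What is called first, only, known or untested is meant among the compounds shown, and "the series" means these compounds.

Of the compounds shown here, two have been measured in an assay on isolated protein for inhibition of leukotriene B4 receptor 1 (Homo sapiens); a lower number here means a stronger inhibitor, a higher number a weaker inhibitor. Compound 1, `CCCc1cc(OCCCOc2ccc(C(C)=O)c(OC)c2CCC)cc2c1OC(C(=O)O)CC2`, gives 41.3 nM in this assay. Compound 2, `CCCc1c(OCCCOc2cc(O)c(C(C)=O)cc2CC)cccc1OCC(=O)O`, gives 67 nM in this assay, the highest of the two numbers, although its gap to compound 1 lies within the scatter, so no ordering can be drawn between them. Compound 3, `CCCc1c(OCCCOc2cc(O)c(C(C)=O)cc2CC)cccc1OC(C)C(=O)O`, has not yet been measured. It differs from compound 2 by methyl in place of hydrogen on a saturated chain carbon bound to a carbonyl carbon and an oxygen on an aromatic ring, which changes the carboxymethoxy group into a 1-carboxyethoxy group. For the measured compounds named here, no measured pair shows this change, so the size of the step is unknown. With the acid retained and only a single carbon added, compound 3 is expected to stay close to compound 2, with a step of a 1.2-fold lower number from compound 2 to compound 3 (0.09 log units; within the scatter) that does not clearly exceed the scatter in either direction. Compound 3 is therefore estimated at 55 nM in this assay, with a range from 18 nM to 180 nM.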

Compound 3, half-maximal inhibitory concentration: 23 nM
Estimate against measurement, compound 3: 2.4-fold (0.38 log units) above; the range from low to high includes it.
By their numbers in this assay, from the lowest: compounds 3, 1 and 2 (each within the scatter of the next, the first and the last beyond it).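

The saturated chain carbon bound to a carbonyl carbon and an oxygen on an aromatic ring proves open to change in this assay: methyl in place of hydrogen there gives a 2.9-fold lower number from compound 2 to compound 3 (0.46 log units; beyond the scatter), a modest step but one beyond the scatter. For the compounds shown here, this is the first reading of any single change, as the two earlier compounds differ in more than one place and could say nothing about this carbon. Turning carboxymethoxy into 1-carboxyethoxy therefore gives a stronger inhibitor, but nothing available accounts for the gain.

From the compounds shown here alone, whether an ethyl group or a second methyl on the same carbon would extend this step or reverse it remains open. It is also unknown whether the methyl would have a similar effect if the carboxylic acid gave way to a tetrazole or an amide.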